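The source may report more compounds than this note shows. Statements on the series, on what has been measured and on what is new or still open speak of the compounds shown alone.

Three related compounds have been tested in a functional assay on the whole organism for antagonist activity, with Mus musculus as the target; on this read-out lower numbers stand for an effect already at smaller amounts and higher numbers for an effect only at larger amounts of compound. Compound 2 (`CN1CCN(CC(=O)NCC(=O)N(C)c2ccc(Cl)cc2C(=O)c2ccccc2Cl)CC1`) gives 59 mg/kg, the highest of the three numbers, so it needs the largest dose. Compound 3 (`NC(C(=O)NCC(=O)Nc1ccc(Cl)cc1C(=O)c1ccccc1)c1ccccc1`) gives a lower 28 mg/kg, and compound 1 (`NCC(=O)NCC(=O)Nc1ccc([N+](=O)[O-])cc1C(=O)c1ccccc1`) gives the lowest, 4.82 mg/kg.

The next compound to be tested is compound 4 (`CCCC(=O)NCC(=O)N(C)c1ccc(Cl)cc1C(=O)c1ccccc1Cl`), which differs from compound 2 in a single place: ethyl in place of 4-methylpiperazin-1-yl on a saturated chain carbon bound to a carbonyl carbon. This puts ethyl in place of 4-methylpiperazin-1-yl on a saturated chain carbon bound to a carbonyl carbon.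

Among the measured compounds shown here, no two measured compounds differ in only one place, so the data show nothing directly about the size of this change. The three measured compounds also differ from one another in several places, which leaves the expectation loose. The estimated step of a 1.5-fold lower number from compound 2 to compound 4 (0.17 log units; within the scatter) is a modest move towards a lower number, expected to stay within the usual scatter. For compound 4 the estimated value is 40 mg/kg, with an expected range of 12 mg/kg to 130 mg/kg.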

Compound 4, dose for half-maximal effect: 0.98 mg/kg
For compound 4 the middle estimate is 41-fold (1.61 log units) above the measured one, and the stated range ends above it.
By their numbers in this assay, from the lowest: compound 4; then compound 1; then compound 3; then compound 2.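

In this assay, among the compounds shown here, putting ethyl in place of 4-methylpiperazin-1-yl on a saturated chain carbon bound to a carbonyl carbon gives a 60-fold lower number from compound 2 to compound 4 (1.78 log units; beyond the scatter) and is the first single change that can be read. This position is therefore far from indifferent to what it carries, and for this pair the effect does not depend on keeping the six-membered ring with its two nitrogens. Nothing shown here gives a reason for the size of this step.

For the compounds shown here, with only two groups compared at this position, it stays open whether the lower number comes from losing the ring or from ethyl itself. A methyl, a longer chain such as butyl, or a small open amine such as dimethylamino in the same place would show how the number follows the group.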